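The source may hold more compounds than are shown below. What is called first, only, known or untested is meant among the compounds shown, and "the series" means these compounds.

Compound 1 `CC(C)N(Cc1cccc(OCCCCCC(=O)O)c1)C(=O)c1ccccc1`: in an ADME assay on HEK293 cells (Homo sapiens) for cytotoxicity, read by CellTiter-Glo and resazurin assay, with a stated time of 72 h (a higher number here means that more compound is needed for the effect, a lower number that less compound is needed), compound 1 gives > 26000 nM, which is a limit of the assay and not a number.
Compound 2 `CC(=O)c1cccc(-c2ccc(C(=O)N(Cc3cccc(OCCCCCC(=O)O)c3)C(C)C)cc2)c1`: in this assay compound 2 gives > 26000 nM, again a limit.
Compound 3 `CC(C)N(Cc1cccc(OCCCCCC(=O)O)c1)C(=O)c1ccc(-c2ccoc2)cc1`: in this assay compound 3 gives > 26000 nM, again a limit.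

Compound 2 therefore stands where every compound measured here stands: at the limit of > 26000 nM in this assay, at which 3 of the 3 values shown sit, so nothing sets it apart from compound 1 or compound 3.

The next compound, compound 4 `CC(C)N(Cc1cccc(OCCCCCC(=O)O)c1)C(=O)c1ccc(-c2cccc(Oc3ccccc3)c2)cc1`, arises from compound 2 by one change, (phenoxy in place of acetyl on an aromatic carbon). The steps already measured among these three compounds are a step that the two limits leave unreadable from compound 1 to compound 2, a step that the two limits leave unreadable from compound 1 to compound 3 and a step that the two limits leave unreadable from compound 2 to compound 3; each of them joins two limits, so no size can be read from any of them. Within the data shown here, none of the measured compounds moved off the limit when the outer ring was changed, and it is expected that swapping acetyl for phenoxy behaves the same way, giving a step that the limit leaves unreadable from compound 2 to compound 4 in this assay. Compound 4 is thus estimated at 30000 nM, within a range from 8000 nM to 100000 nM, most likely reported again as a limit rather than a number.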

Compound 4, half-maximal effective concentration: > 18700 nM
Compound 4: no number, only a limit (the forecaster's own chance of this, stated with the estimate: 70%); the middle value does not contradict the limit.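

In this assay compound 4 gives > 18700 nM, which is a limit of the assay and not a number. Compound 2 also sits at a limit, so the step from compound 2 to compound 4 cannot be read. The compounds shown leave open at what concentration any of the four would reach the half-maximal effect, and whether changing the outer ring alters it.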